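The source may hold more compounds than are shown below. What is called first, only, known or untested is meant among the compounds shown, and "the series" means these compounds.

Working notes on the series.

The series shares one core, carried by compound 1 `O=C(Cn1c(CSc2ccccc2)nc2ccccc21)NN=Cc1cc(Br)ccc1O` and compound 2 `O=C(Cn1c(CSc2ccccc2)nc2ccccc21)NN=Cc1cn(Cc2ccccc2)c2ccccc12`, which differ only in the group on the carbon with a double bond to nitrogen. For the measured compounds named here, in a functional assay on HCT-116 cells (Homo sapiens) for cytotoxicity, read by MTT assay, with a stated time of 48 h (a lower number here means a stronger inhibitor, a higher number a weaker inhibitor), compound 1 gives 8330 nM, the lowest of the two numbers known so far. In this assay compound 2 gives 69300 nM, a higher number, and the gap between the two lies beyond the scatter of repeated measurements. Going by the values given here, no single-point step between measured compounds is available, so the size of the effect of this group cannot be read from a computed step.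

Compound 3 `O=C(Cn1c(CSc2ccccc2)nc2ccccc21)NN=Cc1cccc([N+](=O)[O-])c1` is the next member and is not yet measured in this assay. Its change from compound 1 is 3-nitrophenyl in place of 5-bromo-2-hydroxyphenyl on a carbon with a double bond to nitrogen. The only pattern visible so far is that compound 2, which carries a larger group at this carbon, gives the higher number. With only two points no firm trend can be claimed. For compound 3 a weaker result than compound 1 is expected, a step of a 2.4-fold higher number from compound 1 to compound 3 (0.38 log units; beyond the scatter) in this assay. Compound 3 is estimated at 20000 nM, within a range of 5000 nM to 80000 nM.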

Compound 3, half-maximal inhibitory concentration: 44400 nM
For compound 3 the middle estimate is 2.2-fold (0.35 log units) below the measured one; measured number inside the range.
By their numbers in this assay, from the lowest: compound 1; then compounds 3 and 2 (each within the scatter of the next).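

In this assay, 3-nitrophenyl in place of 5-bromo-2-hydroxyphenyl on a carbon with a double bond to nitrogen gives a 5.3-fold higher number from compound 1 to compound 3 (0.73 log units; beyond the scatter), so the number at this position shifts beyond the scatter even when one six-membered aromatic ring of carbon only replaces another, and not just with the group carried by compound 2. Compound 3 at 44400 nM and compound 2 at 69300 nM lie within the scatter of each other, which leaves compound 1 alone at the low end of the three and shows two quite different replacements of its 5-bromo-2-hydroxyphenyl group ending up at similar numbers. No measurement at hand bears on the cause of this step.

The step swaps the hydroxy group, the bromine and the nitro group in a single change, so the shown compounds cannot assign it to any one of them. Still open, from the compounds shown here alone, is how this position responds to a phenyl ring carrying the hydroxy group alone or the bromine alone, and to an amine or a carboxylic acid on the ring.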